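Swapping the amide tail: a furan in place of phenylbutyl

The compounds below may be only part of what the source reports. "The series", "measured", "known", "first", "only" and "open" are said of these compounds alone.

Measured so far in a functional assay on HepG2 cells (Homo sapiens) for inhibition, read by MTT assay, with a stated time of 48 h; on this read-out higher numbers stand for weaker inhibition and lower numbers for stronger inhibition:
- compound 1 `CCCC(=O)Nc1ccc(N2CCN(c3ccc(OC[C@@H]4CO[C@@](Cn5cncn5)(c5ccc(Cl)cc5Cl)O4)cc3)CC2)cc1`: 9930 nM
- compound 2 `O=C(CCCCc1ccccc1)Nc1ccc(N2CCN(c3ccc(OC[C@@H]4CO[C@@](Cn5cncn5)(c5ccc(Cl)cc5Cl)O4)cc3)CC2)cc1`: 7010 nM

Compound 2 and compound 1 differ by a 1.4-fold lower number from compound 1 to compound 2 (0.15 log units; within the scatter), so the two numbers cannot be told apart. Compound 3 `O=C(Nc1ccc(N2CCN(c3ccc(OC[C@@H]4CO[C@@](Cn5cncn5)(c5ccc(Cl)cc5Cl)O4)cc3)CC2)cc1)c1ccco1` carries furan-2-yl in place of 4-phenylbutyl on a carbonyl carbon. For the measured compounds named here, the single measured step concerns lengthening the chain, not replacing it with an aromatic ring, so it bears only loosely on this change; nothing here argues for a large shift. For compound 3 the expected step is a 1.3-fold higher number from compound 2 to compound 3 (0.11 log units; within the scatter), and the estimate in this assay is 9000 nM, within a range from 4000 nM to 20000 nM.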

Compound 3, half-maximal inhibitory concentration: 22300 nM
The estimate for compound 3 lay 2.5-fold (0.39 log units) below the measured number, and the stated range ends below it.
By their numbers in this assay, from the lowest: compounds 2 and 1 (each within the scatter of the next); then compound 3.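

In this assay, for the compounds shown here, this is the first change at this carbonyl carbon to go beyond the scatter: a 3.2-fold higher number from compound 2 to compound 3 (0.50 log units; beyond the scatter) and a 2.2-fold higher number from compound 1 to compound 3 (0.35 log units; beyond the scatter) are both modest steps towards weaker inhibition. Furan-2-yl therefore gives a higher number than either the propyl or the 4-phenylbutyl tail, even though those two chains could not be told apart. Nothing available explains this shift. Still open, on these data alone, is whether the higher number belongs to furan-2-yl alone or also to a phenyl or thiophene ring on this carbonyl carbon.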